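Piperidin-1-yl Replacing a Substituted Pyrrolidine in Compound 4

The source may report more compounds than this note shows. Statements on the series, on what has been measured and on what is new or still open speak of the compounds shown alone.

In a functional assay on Caco-2 cells (Homo sapiens) for inhibition, read by MTT assay, with a stated time of 48 h, tested at 10 uM (on this read-out higher numbers stand for more inhibition of growth at the one concentration tested and lower numbers for less inhibition of growth), compound 1 (`CCN(CC)Cc1c(O)c([C@H]2CCN(C)C[C@H]2O)c2oc(C)cc(=O)c2c1O`) gives 17%, compound 2 (`Cc1cc(=O)c2c(O)c(CN3CCCC3CO)c(O)c([C@H]3CCN(C)C[C@H]3O)c2o1`) gives 19% and compound 3 (`Cc1cc(=O)c2c(O)c(CN3CC(O)CC3C(=O)O)c(O)c([C@H]3CCN(C)C[C@H]3O)c2o1`) gives 19%. Compound 3 thus stands level with compound 2 and within the scatter of compound 1. Compound 4 (`Cc1cc(=O)c2c(O)c(CN3CCCCC3)c(O)c([C@H]3CCN(C)C[C@H]3O)c2o1`) has not yet been measured. It carries piperidin-1-yl in place of 2-carboxy-4-hydroxypyrrolidin-1-yl on a saturated chain carbon bound to an aromatic carbon. Three measured steps exchange the group at this same place: a number 2 percentage points higher from compound 1 to compound 2 (within the scatter), a number 2 percentage points higher from compound 1 to compound 3 (within the scatter) and no change at the digits printed from compound 2 to compound 3 (within the scatter). None of them leaves the scatter. The diethylamino group of compound 1, like piperidin-1-yl, holds only carbon and nitrogen, and compound 1 gives 17%. No six-membered ring has been tested at this place, so the range is kept wide. The expected result in this assay is a number 1 percentage points higher from compound 3 to compound 4 (within the scatter), with no shift beyond the scatter anticipated. For compound 4 the estimated value is 20%, with an expected range from 9% to 33%.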

Compound 4, percent growth inhibition at one concentration: 22%
Beside the measured number, compound 4's estimate is 2 percentage points below it; the range from low to high includes it.
By their numbers in this assay, from the lowest: compounds 1, 2, 3 and 4 (each within the scatter of the next).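

In this assay piperidin-1-yl brings a six-membered non-aromatic ring to this place, on a saturated chain carbon bound to an aromatic carbon, and the number stays within the scatter of all three earlier groups (a number 3 percentage points higher from compound 3 to compound 4 (within the scatter)) and (a number 3 percentage points higher from compound 2 to compound 4 (within the scatter)) and (a number 5 percentage points higher from compound 1 to compound 4 (within the scatter)). Piperidin-1-yl in place of 2-carboxy-4-hydroxypyrrolidin-1-yl also takes away the oxygen atoms and hydrogen-bond donors of that group, and this exchange too stays within the scatter, so across these four compounds no exchange at this place has yet left it. No evidence bearing on this result is at hand.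

The compounds shown leave open whether any group at this place can move the number beyond the scatter, such as morpholin-4-yl, piperazin-1-yl or the seven-membered azepan-1-yl. They also leave open whether these four compounds would stay this close at concentrations other than the one tested.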